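Dipropylamino to (3-chlorophenyl)amino across two related cores

The source may hold more compounds than are shown below. What is called first, only, known or untested is meant among the compounds shown, and "the series" means these compounds.

The set holds two cores built from the same atoms joined differently; the difference between the two cores is not broken down here. Compound 1 `CCCN(CCC)C1=CC(=O)c2nc3n(c2C1=O)[C@H]1OC[C@@H](O)[C@H]1OC3` carries dipropylamino and compound 2 `O=C1C=C(Nc2cccc(Cl)c2)C(=O)c2c1nc1n2[C@H]2OC[C@@H](O)[C@H]2OC1` carries (3-chlorophenyl)amino on the first core; compound 3 `CCCN(CCC)C1=CC(=O)c2c(nc3n2[C@H]2OC[C@@H](O)[C@H]2OC3)C1=O` carries dipropylamino and compound 4 `O=C1C(Nc2cccc(Cl)c2)=CC(=O)c2c1nc1n2[C@H]2OC[C@@H](O)[C@H]2OC1` carries (3-chlorophenyl)amino on the second. In a functional assay on MGC-803 cells (Homo sapiens) for inhibition, read by sulforhodamine B assay (a lower number here means a stronger inhibitor, a higher number a weaker inhibitor), compound 1 reaches only the limit of the assay, > 16000 nM. In this assay compound 2 gives 1770 nM. The change (3-chlorophenyl)amino in place of dipropylamino on a double-bonded ring carbon thus gives an at least 9.0-fold lower number from compound 1 to compound 2 (0.95 log units; beyond the scatter). In this assay compound 3 likewise reaches only the limit, > 16000 nM. Compound 4 has not been measured; it carries the same change, ((3-chlorophenyl)amino in place of dipropylamino on a double-bonded ring carbon), and the place is described in the same words, so this is the same change made on the other core. For the measured compounds named here, the expectation for it rests on the single measured instance, an at least 9.0-fold lower number from compound 1 to compound 2 (0.95 log units; beyond the scatter), and on (the limit of > 16000 nM in this assay, at which 2 of the 3 values shown sit), which leaves the true size of that step open and leaves the starting point of compound 3 open as well. For compound 4 the expected step is an at least 6.4-fold lower number from compound 3 to compound 4 (0.80 log units; beyond the scatter) in this assay. Compound 4 is estimated at 2500 nM in this assay, with a range from 700 nM to 12000 nM, kept wide because the limit of > 16000 nM in this assay, at which 2 of the 3 values shown sit, fixes no number on the dipropylamino side of either core.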

Compound 4, half-maximal inhibitory concentration: 1530 nM
For compound 4 the middle estimate is 1.6-fold (0.21 log units) above the measured one; the range from low to high includes it.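

In this assay, (3-chlorophenyl)amino in place of dipropylamino on a double-bonded ring carbon gives an at least 10-fold lower number from compound 3 to compound 4 (1.01 log units; beyond the scatter), so the change made on the second core again lowers the number beyond the scatter. The direction of the change therefore holds on both cores, but this rests on just one pair of compounds per core, and the two steps cannot be ranked by size: the same change on two cores in this assay, an at least 9.0-fold lower number (0.95 log units; beyond the scatter) from compound 1 to compound 2 and an at least 10-fold lower number (1.01 log units; beyond the scatter) from compound 3 to compound 4; the limit leaves it open whether they differ. Neither step has a fixed size, so these data show that the direction carries over from one core to the other, not that the size of the step does: the limit of > 16000 nM in this assay, at which 2 of the 4 values shown sit.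

The compounds shown leave open whether the lower numbers depend on the aromatic ring, on the chlorine or on the hydrogen-bond donor of the entering group, since these all enter together; phenylamino without the chlorine, or benzylamino, would begin to separate them. They also leave open whether a smaller amine on the same carbon, such as dimethylamino or morpholine, would give a measurable number on either core, which would put a firm starting point under the step.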